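Propargylamine series: halophenyl side chain variation

The compounds below may be only part of what the source reports. "The series", "measured", "known", "first", "only" and "open" are said of these compounds alone.

Compound 1 `C#CCNC1CCc2c(SCCc3cccc(Br)c3)cccc21` and compound 2 `C#CCNC1CCc2c(SCc3ccc(C(F)(F)F)cc3)cccc21` share one core. In an ADME assay on isolated protein for inhibition of Amine oxidase [flavin-containing] B (Homo sapiens) (a lower number here means a stronger inhibitor, a higher number a weaker inhibitor), compound 1 gives 620 nM; in this assay compound 2 gives 930 nM, and the two numbers lie within the scatter of each other, so neither stands apart. Compound 3 `C#CCNC1CCc2c(SCCc3ccc(Cl)c(Cl)c3)cccc21` is not yet measured in this assay. Relative to compound 1 it carries 3,4-dichlorophenyl in place of 3-bromophenyl on a saturated chain carbon, two bonds along the chain from a sulfur. Within the data shown here, no step between measured compounds covers this change, so the expectation is a step toward a lower number, estimated at a 1.4-fold lower number from compound 1 to compound 3 (0.14 log units; within the scatter), probably no larger than the scatter. Compound 3 is therefore expected at 450 nM, within 150 nM to 1500 nM.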

Compound 3, half-maximal inhibitory concentration: 2820 nM
Estimate against measurement, compound 3: 6.3-fold (0.80 log units) below; the whole stated range lies below it.
By their numbers in this assay, from the lowest: compounds 1 and 2 (each within the scatter of the next); then compound 3.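

At the saturated chain carbon two bonds along the chain from a sulfur, the substitution on the phenyl ring matters in this assay. Among these compounds, with the shared core and chain held constant, 3,4-dichlorophenyl in place of 3-bromophenyl gives a 4.5-fold higher number from compound 1 to compound 3 (0.66 log units; beyond the scatter) and is the first step that can be read at this position. No measured evidence bears on the origin of this step.

The compounds shown do not separate the effect of losing bromine from that of having two chlorines. A 3-chlorophenyl or 4-bromophenyl group on the same chain would test which part of the change carries the step.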